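Swapping bromo for fluoro on the anilino ring of compound 1

This account rests on a few compounds, and the source may have more. Where it says the series, first, only, none or still open, it means among the compounds named here.

Compound 1 `O=[N+]([O-])c1ccc(Oc2ccc(/C=N/NC(=S)Nc3ccc(Br)cc3)cc2)cc1` is the most polar of the three compounds measured in a physicochemical assay for lipophilicity, in phosphate buffer, measured as octanol-water partition, with a stated time of 24 h; a lower number here means a more polar compound, a higher number a more lipophilic compound: in that assay compound 1 gives 5.68. Compound 3 `S=C(N/N=C/c1ccc(Oc2ccc(Br)cc2)cc1)Nc1ccc(Br)cc1` gives 6.53 in this assay, the step of a number 0.85 log units higher from compound 1 to compound 3 (beyond the scatter) being modest, and compound 2 `Cc1cc(Oc2ccc(/C=N/NC(=S)Nc3ccc(Br)cc3)cc2)ccc1Cl` gives 7.89, the step of a number 2.21 log units higher from compound 1 to compound 2 (beyond the scatter) being large. Compound 4 `O=[N+]([O-])c1ccc(Oc2ccc(/C=N/NC(=S)Nc3ccc(F)cc3)cc2)cc1` differs from compound 1 in one place: fluoro in place of bromo on an aromatic carbon. Among the measured compounds shown here, no measured step exchanges one halogen for another on the anilino ring; the nearest is a number 0.85 log units higher from compound 1 to compound 3 (beyond the scatter), where a bromo enters on an aromatic carbon of the other ring, and a number 1.36 log units lower from compound 2 to compound 3 (beyond the scatter), where a 4-bromophenyl replaces a 4-chloro-3-methylphenyl. Both show that a single substituent on an aromatic carbon moves this assay beyond the scatter. Compound 4 is therefore expected to fall below compound 1 by a modest amount, a number 0.68 log units lower from compound 1 to compound 4 (beyond the scatter). The estimate for compound 4 in this assay is 5, within a range from 4.4 to 5.6.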

Compound 4, partition coefficient: 4.89
The estimate for compound 4 lay 0.11 log units above the measured number, and the stated range covers the measured number.
By their numbers in this assay, from the lowest: compound 4; then compound 1; then compound 3; then compound 2.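

With (4-fluorophenyl)amino in place of (4-bromophenyl)amino, the compounds shown now include a change at this position, which had carried bromo in compounds 1, 2 and 3. In this assay, this exchange of one halogen for another gives a number 0.79 log units lower from compound 1 to compound 4 (beyond the scatter), so this position also moves the read-out beyond the scatter. The step is modest, as is a number 0.85 log units higher from compound 1 to compound 3 (beyond the scatter), although that step is in the opposite direction and at the other end of the molecule. Nothing given here bears on the reason for the new step.

The compounds shown leave open how an amine or a methoxy group in place of bromo on this aromatic carbon would read. They also leave open whether fluoro in place of bromo would give a similar step on the core of compound 3 or compound 2.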